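A few compounds are considered here, and "the series" means these few. Any claim that something is new, unique, unknown or untested is made for them only; others in the source may bear on it.

Measured in a functional assay on SK-BR-3 cells (Homo sapiens) for antiproliferative activity; a higher number here means a weaker inhibitor, a lower number a stronger inhibitor:
- compound 1 `CC(C)=CCc1cc(C(=O)Nc2cc3ccc(OCCCNC(C)C)c(C)c3oc2=O)ccc1O`: 750 nM
- compound 2 `CC(C)=CCc1cc(C(=O)Nc2cc3ccc(OCCCN(C)C(C)C)c(C)c3oc2=O)ccc1O`: 570 nM
- compound 3 `CC(C)=CCc1cc(C(=O)Nc2cc3ccc(OCCCN(C)C(C)(C)C)c(C)c3oc2=O)ccc1O`: 880 nM

Compound 3 stands level with the other two compounds: a 1.2-fold higher number from compound 1 to compound 3 (0.07 log units; within the scatter), and a 1.5-fold higher number from compound 2 to compound 3 (0.19 log units; within the scatter). The remaining pair behaves the same way: a 1.3-fold lower number from compound 1 to compound 2 (0.12 log units; within the scatter).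

Still unmeasured is compound 4 `CC(C)=CCc1cc(C(=O)Nc2cc3ccc(OCCCNCC(N)=O)c(C)c3oc2=O)ccc1O`, which differs from compound 3 as follows: (carbamoylmethyl)amino in place of methyl(tert-butyl)amino on a saturated chain carbon, three bonds along the chain from an oxygen on an aromatic ring. Here (carbamoylmethyl)amino takes the place of methyl(tert-butyl)amino on a saturated chain carbon, three bonds along the chain from an oxygen on an aromatic ring.

All three measured steps change only the amine group at this place, and none stepped outside the scatter. For the measured compounds named here, they bear on the new change only indirectly, since no measured compound carries a carbamoyl group. That leaves no measured support for a shift in either direction, although the new group makes the uncertainty wide. The expected step is small, with nothing beyond the scatter anticipated: a 1.1-fold higher number from compound 3 to compound 4 (0.06 log units; within the scatter). For compound 4 the estimated value is 1000 nM, with an expected range of 300 nM to 3500 nM.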

Compound 4, half-maximal inhibitory concentration: 2290 nM
Beside the measured number, compound 4's estimate is 2.3-fold (0.36 log units) below it, within the range that was stated.
By their numbers in this assay, from the lowest: compounds 2, 1 and 3 (each within the scatter of the next); then compound 4.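

In this assay, this place on the saturated chain carbon, three bonds along the chain from an oxygen on an aromatic ring, now shows a response to the amine group: (carbamoylmethyl)amino gives a 2.6-fold higher number from compound 3 to compound 4 (0.42 log units; beyond the scatter) and a 4.0-fold higher number from compound 2 to compound 4 (0.60 log units; beyond the scatter), whereas the steps among isopropylamino, isopropyl(methyl)amino and methyl(tert-butyl)amino all stayed within the scatter. The most direct reading is carbamoylmethyl in place of isopropyl on an amine nitrogen, which leaves the hydrogen on that nitrogen in place and gives a 3.1-fold higher number from compound 1 to compound 4 (0.48 log units; beyond the scatter), so the tolerance seen among the three alkylated amines does not extend to this group, although each of these steps is only modest. No data are at hand that account for the weaker result.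

Open, on these data alone, is whether the loss follows the terminal amide itself or simply the removal of the branched alkyl groups, a question that a plain ethylamino or a 2-hydroxyethylamino group at the same place would help to settle. Also open, as far as these compounds go, is how a carboxylic acid, or the same amide carried on a longer chain, would read in this assay.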